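Carbamate-linked series: aryl change on the fused core

This account rests on a few compounds, and the source may have more. Where it says the series, first, only, none or still open, it means among the compounds named here.

Compound 3 `CC(C)OC(=O)N1CCC(Oc2ncnc3c2CCN3c2ccc(S(C)(=O)=O)cn2)CC1` is taken as the reference point. In a functional assay on CHO-K1 cells for agonist activity at Glucose-dependent insulinotropic receptor (Homo sapiens), read by a luciferase reporter, with a stated time of 5 h (on this read-out lower numbers stand for an effect already at smaller amounts and higher numbers for an effect only at larger amounts of compound), compound 3 gives 126 nM. Compound 1 `CCOC(=O)N1CCC(Oc2ncnc3c2CCN3c2ccc(S(C)(=O)=O)cc2F)CC1` gives 251 nM, a gap within the usual scatter, so no order between the two is claimed. Compound 2 `CS(=O)(=O)c1ccc(N2CCc3c(OC4CCN(C(=O)OCCF)CC4)ncnc32)c(F)c1` gives 501 nM, a gap beyond the scatter. Going by the values given here, the only single-point step measured so far, a 2.0-fold higher number from compound 1 to compound 2 (0.30 log units; within the scatter), concerns the carbamate chain and not the aryl ring on the ring nitrogen; compound 1 and compound 3 differ in two places at once, so their gap is not a clean step.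

The unmeasured compound 4 `Cc1cc(S(C)(=O)=O)ccc1N1CCc2c(OC3CCN(C(=O)OC(C)C)CC3)ncnc21` differs from compound 3 in one place: 2-methyl-4-(methylsulfonyl)phenyl in place of 5-(methylsulfonyl)pyridin-2-yl on a nitrogen on an aromatic ring in a ring.

Among the compounds with values here, no measured step bears directly on this exchange. The numbers for compound 1 and compound 3 show that a carbon-only ring on that nitrogen is compatible with a small number, and the expectation is therefore a 1.6-fold higher number from compound 3 to compound 4 (0.20 log units; within the scatter), a step not clearly beyond the scatter. Compound 4 is estimated at 200 nM, with a range of 60 nM to 650 nM.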

Compound 4, half-maximal effective concentration: 100 nM
The estimate for compound 4 lay 2.0-fold (0.30 log units) above the measured number; the measured number falls inside the stated range.
By their numbers in this assay, from the lowest: compounds 4, 3, 1 and 2 (each within the scatter of the next, the first and the last beyond it).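

In this assay, going by these compounds alone, 2-methyl-4-(methylsulfonyl)phenyl in place of 5-(methylsulfonyl)pyridin-2-yl on the nitrogen of the five-membered non-aromatic ring gives a 1.3-fold lower number from compound 3 to compound 4 (0.10 log units; within the scatter) and is the first single-place step measured at this position. With the rest of compound 3 held constant, the aromatic ring with one hetero atom and the carbon-only ring bearing a methyl are not told apart at this position, although the change removes the ring nitrogen and adds the methyl together. No supporting data on this exchange are available to explain the result.

On these data alone, the separate contributions of the ring nitrogen and the methyl remain open, as a single change could show. Also open, as far as these compounds go, is whether a nitrile, an amide or a carboxylic acid could stand in place of the methylsulfonyl group on this ring.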